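A Charged Sulfur Group Replaces Bromine on a Macrocycle

The source may hold more compounds than are shown below. What is called first, only, known or untested is meant among the compounds shown, and "the series" means these compounds.

Compound 1, `NCCCCC1NC(=O)CNC(=O)c2cc(ccc2CBr)NC1=O`; in an assay on isolated protein for binding affinity to serine protease 1 (Bos taurus) (a higher number here means a weaker inhibitor, a lower number a stronger inhibitor), compound 1 gives 80000 nM.
Compound 2, `N=C(N)NCCCC1NC(=O)CNC(=O)c2cc(ccc2CBr)NC1=O`; in this assay compound 2 gives 55000 nM.

Both compounds share the same ring-shaped core and differ only in the chain that carries the basic end group. That step, a 1.5-fold lower number from compound 1 to compound 2 (0.16 log units; within the scatter), is within the scatter, so the two numbers cannot be told apart and neither compound can be ranked above the other; compound 1 simply carries the larger of the two numbers.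

Compound 3, `C[S+](Cc1ccc2cc1C(=O)NCC(=O)NC(CCCCN)C(=O)N2)c1ccccc1`, has not been measured. It differs from compound 1 at another position: a group of 8 heavy atoms (7 carbon, 1 sulfur; one six-membered aromatic ring of carbon only) in place of one bromine atom, on a saturated chain carbon bound to an aromatic carbon. For the measured compounds named here, no measured step touches this position, and the single known step concerns a different part of the molecule, so the data give no direction for the change. Going by the values given here, the only anchor is the value of compound 1 in this assay. The step from compound 1 to compound 3 is therefore expected to be a 1.3-fold lower number from compound 1 to compound 3 (0.12 log units; within the scatter), with wide uncertainty. Compound 3 is estimated at 60000 nM, in the range 12000 nM to 300000 nM.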

Compound 3, inhibition constant: 87000 nM
Compound 3: the middle estimate sits 1.5-fold (0.16 log units) below what was measured; the range from low to high includes it.
By their numbers in this assay, from the lowest: compounds 2, 1 and 3 (each within the scatter of the next).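

In this assay, for the compounds shown here, this is the first reading at the saturated chain carbon bound to an aromatic carbon, since compound 1 and compound 2 both carry the bromo group there: a 1.1-fold higher number from compound 1 to compound 3 (0.04 log units; within the scatter). Exchanging one bromine atom for a much larger group of 8 heavy atoms, with a six-membered aromatic ring and a net charge of +1, therefore leaves a number that cannot be told apart from that of compound 1, so this single change shows neither a gain nor a loss at this position. Nothing available accounts for the two groups reading alike, and no measurement of any property of either group bears on it.

The compounds shown leave open how groups of other kinds would read at this position, such as a neutral thioether with the same aromatic ring, a simple amine or a carboxylic acid. They also leave open whether the sulfur group would read the same on the core of compound 2, with its different basic chain.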